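Working notes: nitro in place of chloro

The source may report more compounds than this note shows. Statements on the series, on what has been measured and on what is new or still open speak of the compounds shown alone.

- compound 1 `COc1ccc(N2CCN(C(=S)SCc3ccc4nc(N)nc(N)c4c3)CC2)cc1`: 1590 nM
- compound 2 `Nc1nc(N)c2cc(CSC(=S)N3CCN(c4ccc(Cl)cc4)CC3)ccc2n1`: 5210 nM

Within the data shown here, in a functional assay on A549 cells (Homo sapiens) for antiproliferative activity, read by MTT assay, with a stated time of 72 h (on this read-out lower numbers stand for stronger inhibition and higher numbers for weaker inhibition), compound 2 holds the higher of only two numbers, and compound 1 is its nearest neighbour. The next analogue, compound 3 `Nc1nc(N)c2cc(CSC(=S)N3CCN(c4ccc([N+](=O)[O-])cc4)CC3)ccc2n1`, has nitro in place of chloro on an aromatic carbon, para to a large group (nitro in place of chloro on an aromatic carbon). Among the measured compounds shown here, one measured step bears on this change: a 3.3-fold higher number from compound 1 to compound 2 (0.52 log units; beyond the scatter), with chloro in place of methoxy on an aromatic carbon. For the measured compounds named here, that single modest step shows that a swap of this kind can move the number, but no measured step involves nitro. In this assay a step of similar or smaller size is therefore expected, with only a slight lean towards a lower number. The estimated step is a 1.4-fold lower number from compound 2 to compound 3 (0.14 log units; within the scatter). For compound 3 the expected value is 3800 nM, within an estimated range of 1300 nM to 11000 nM.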

Compound 3, half-maximal inhibitory concentration: 1910 nM
Compound 3: middle estimate off by 2.0-fold (0.30 log units), on the high side; the measured number falls inside the stated range.
By their numbers in this assay, from the lowest: compounds 1 and 3 (each within the scatter of the next); then compound 2.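

In this assay, replacing 4-chlorophenyl with 4-nitrophenyl gives a 2.7-fold lower number from compound 2 to compound 3 (0.44 log units; beyond the scatter) and shows that a second group on this aromatic carbon, para to a large group, can separate from chloro beyond the scatter. The comparison of nitro with methoxy gives a 1.2-fold higher number from compound 1 to compound 3 (0.08 log units; within the scatter) and so does not separate these two groups, a distinction that the earlier pair could not address. Among the three compounds, chloro alone stands apart, with compound 2 holding the highest number, while compounds 1 and 3 remain level within the scatter.

Going by these compounds, whether an amine, a carboxylic acid or a plain hydrogen at this position would sit with compounds 1 and 3 or with compound 2 remains open. No measurement among these data explains why chloro stands apart from methoxy and nitro.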